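This account rests on a few compounds, and the source may have more. Where it says the series, first, only, none or still open, it means among the compounds named here.

Measured so far:
- compound 1 `N#C/C(=C\c1ccco1)C(=O)NCc1ccc(Cl)c(Cl)c1`: > 50000 nM
- compound 2 `COc1ccc(CNC(=O)/C(C#N)=C/c2ccc(Cl)o2)cc1`: 9000 nM
- compound 3 `COc1ccc(CNC(=O)/C(C#N)=C/c2ccc3ccccc3c2)cc1`: 37000 nM

In a functional assay on A-431 cells (Homo sapiens) for inhibition, read by MTT assay, with a stated time of 72 h (a lower number here means a stronger inhibitor of growth, a higher number a weaker inhibitor of growth), compound 1 reaches only the limit of the assay, > 50000 nM, so no number is known for it; (the limit of > 50000 nM in this assay, at which 1 of the 3 values shown sits). Compound 2 gives 9000 nM and compound 3 gives 37000 nM; neither pair is a single-change step from compound 1, so their values are only a rough frame for the series.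

Compound 4 `COc1ccc(/C=C(\C#N)C(=O)NCc2ccc(Cl)c(Cl)c2)cc1` differs from compound 1 by 4-methoxyphenyl in place of furan-2-yl on a double-bonded chain carbon bound to a double-bonded chain carbon. Within the data shown here, no measured step covers this change. Compound 4 is expected to land near 30000 nM, within 8000 nM to 100000 nM, an estimated step of an at least 1.6-fold lower number from compound 1 to compound 4 (0.22 log units; that floor lies within the scatter) of uncertain direction and possibly within the scatter.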

Compound 4, concentration for 50% growth inhibition: 90000 nM
The estimate for compound 4 lay 3.0-fold (0.48 log units) below the measured number; measured number inside the range.
By their numbers in this assay, from the lowest: compound 2; then compound 3; then compound 4.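

In this assay, among these compounds, compound 1 gives only the limit > 50000 nM and no number, so no step to compound 4 can be read: the limit of > 50000 nM in this assay, at which 1 of the 4 values shown sits.
The compounds shown leave open how far 4-methoxyphenyl in place of furan-2-yl shifts growth inhibition on the core of compound 1.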